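Removing the methyl from compound 3

The compounds below may be only part of what the source reports. "The series", "measured", "known", "first", "only" and "open" are said of these compounds alone.

In a functional assay on VCaP cells (Homo sapiens) for antiproliferative activity, read by CCK-8 assay, with a stated time of 6 days (on this read-out higher numbers stand for weaker inhibition and lower numbers for stronger inhibition), compound 3 `CCN(c1ccc(C#N)c(Cl)c1)c1cc(-c2cncnc2)ccc1C` gives 3920 nM and compound 1 `CCN(c1ccc(C#N)c(Cl)c1)c1cc(-c2ccncc2)ccc1C` gives 2900 nM, two values within the scatter of each other. For compound 2 `CCN(c1cccc(-c2ccccc2)c1)c1ccc(C#N)c(Cl)c1` the entry reads "not determined" (no result reported), so it offers no number for comparison.

Compound 4 `CCN(c1cccc(-c2cncnc2)c1)c1ccc(C#N)c(Cl)c1` differs from compound 3 by hydrogen in place of methyl on an aromatic carbon, ortho to a large group and para to a pyrimidin-5-yl group.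

Among the compounds with values here, the only measured step, a 1.4-fold higher number from compound 1 to compound 3 (0.13 log units; within the scatter), exchanges pyridin-4-yl for pyrimidin-5-yl and leaves the methyl untouched. Within the data shown here, no measured pair therefore isolates the loss of the methyl, and the size and direction of this change remain open. With no evidence for a shift in either direction, the expected change in this assay is a 1.1-fold higher number from compound 3 to compound 4 (0.06 log units; within the scatter), which is no step beyond the scatter, though with wide uncertainty. For compound 4 the estimated value is 4500 nM, with an expected range of 1500 nM to 13000 nM.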

Compound 4, half-maximal inhibitory concentration: > 30000 nM
Compound 4 ended at the assay's limit; the forecaster's own chance of this, stated with the estimate: 15%; at least 6.6-fold (0.82 log units) between middle value and limit.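

Hydrogen in place of methyl on this aromatic carbon, ortho to a large group and para to a pyrimidin-5-yl group, gives an at least 7.6-fold higher number from compound 3 to compound 4 (0.88 log units; beyond the scatter). Within the data shown here, this is the first single change to go beyond the scatter, whereas exchanging pyridin-4-yl for pyrimidin-5-yl gives a 1.4-fold higher number from compound 1 to compound 3 (0.13 log units; within the scatter). In this assay, the entry for compound 4 is a limit and not a number, so the step has a lower bound but no known full size: the limit of > 30000 nM in this assay, at which 1 of the 4 values shown sits.

As far as these compounds go, it remains open whether ethyl, methoxy or chlorine on this carbon would keep the numbers of compound 1 and compound 3. Compound 2 has no reported result, so the compounds shown also leave open whether losing the methyl has a similar effect with pyridin-4-yl in place of pyrimidin-5-yl.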